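A few compounds are considered here, and "the series" means these few. Any claim that something is new, unique, unknown or untested is made for them only; others in the source may bear on it.

So far, two compounds that share one core have been measured in an ADME assay on MT4 cells (Homo sapiens) for cytotoxicity, read by MTT assay, with a stated time of 4 days; a lower number here means that less compound is tolerated, a higher number that more compound is tolerated. In it, compound 1 `C/C(=N\NC(=O)COc1cccc2ccccc12)c1ccc(Cl)cc1` gives 4.07 ug/mL and compound 2 `C/C(=N\NC(=O)COc1cccc2ccccc12)c1ccccc1O` gives 11.3 ug/mL, which makes compound 2 the higher of the two numbers. Compound 3 `C/C(=N\NC(=O)COc1cccc2ccccc12)c1ccc(Br)cc1` has not yet been measured. It differs from compound 2 in one place, on a carbon with a double bond to nitrogen, where 4-bromophenyl stands in place of 2-hydroxyphenyl: 4-bromophenyl in place of 2-hydroxyphenyl on a carbon with a double bond to nitrogen.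

Among the measured compounds shown here, only one measured step bears on this change: a 2.8-fold higher number from compound 1 to compound 2 (0.44 log units; beyond the scatter). That step brought in the same 2-hydroxyphenyl that compound 3 gives up, replacing 4-chlorophenyl, a group named much like the incoming 4-bromophenyl. Read backwards, it suggests a move of similar size towards a lower number, though a single step is thin support and chlorine and bromine are different atoms. The estimated change is therefore a drop, a 2.5-fold lower number from compound 2 to compound 3 (0.40 log units; beyond the scatter). For compound 3 the expected value is 4.5 ug/mL, with an estimated range from 2 ug/mL to 10 ug/mL.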

Compound 3, half-maximal cytotoxic concentration: 77.6 ug/mL
The estimate for compound 3 lay 17-fold (1.24 log units) below the measured number; the whole stated range lies below it.
By their numbers in this assay, from the lowest: compound 1; then compound 2; then compound 3.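

The halogen on this ring matters far more than its name suggests: in this assay, bromo in place of chloro on an aromatic carbon gives a 19-fold higher number from compound 1 to compound 3 (1.28 log units; beyond the scatter), the largest step in the series, so 4-chlorophenyl is a poor stand-in for 4-bromophenyl here. The other change at this position, 4-bromophenyl in place of 2-hydroxyphenyl, gives a 6.9-fold higher number from compound 2 to compound 3 (0.84 log units; beyond the scatter), so the compound with 2-hydroxyphenyl falls between the two halogen compounds and the two halogens do not form one group on this scale. Among the compounds shown here, nothing measured here explains why a single atom swap moves the number so far.

On these data alone, it remains open where an unsubstituted phenyl, 4-fluorophenyl or 4-iodophenyl would fall, and so whether compound 3 follows a trend among the halogens or stands alone. A 4-hydroxyphenyl or 2-bromophenyl group would also help separate what the substituent contributes from what its place on the ring contributes, since compound 2 differs from compound 1 and compound 3 in both.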